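The source may report more compounds than this note shows. Statements on the series, on what has been measured and on what is new or still open speak of the compounds shown alone.

Compound 1 `Cc1nc(N)c2c(-c3ccoc3)cn([C@@H]3O[C@H](CO)[C@@H](O)[C@H]3O)c2n1`: > 20000 nM
Compound 2 `Cc1nc(N)c2c(-c3cc4ccccc4o3)cn([C@@H]3O[C@H](CO)[C@@H](O)[C@H]3O)c2n1`: > 20000 nM

In a functional assay on A549 cells (Homo sapiens), read by MTT assay, with a stated time of 72 h (a higher number here means a weaker inhibitor, a lower number a stronger inhibitor), compound 2 gives > 20000 nM, which is a limit and not a number. Compound 1 gives > 20000 nM, also a limit. Going by the values given here, the series so far therefore stands at the limit of > 20000 nM in this assay, at which 2 of the 2 values shown sit. Among the compounds with values here, the only measured step is a step that the two limits leave unreadable from compound 1 to compound 2.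

Compound 3 `Cc1nc(N)c2c(I)cn([C@@H]3O[C@H](CO)[C@@H](O)[C@H]3O)c2n1` carries iodo in place of 1-benzofuran-2-yl on an aromatic carbon. Within the data shown here, no measured step gives a size to carry over, so no clear move in either direction is expected in this assay. The expected step is a number no higher from compound 2 to compound 3 (the limit leaves the size open). For compound 3 the estimate is 20000 nM, with an expected range from 5000 nM to 50000 nM.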

Compound 3, half-maximal inhibitory concentration: 12100 nM
Beside the measured number, compound 3's estimate is 1.7-fold (0.22 log units) above it; measured number inside the range.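

In this assay, going by these compounds alone, iodo on this aromatic carbon gives the first readable number at the position, with an at least 1.6-fold lower number from compound 2 to compound 3 (0.21 log units; that floor lies within the scatter) and an at least 1.6-fold lower number from compound 1 to compound 3 (0.21 log units; that floor lies within the scatter). On these data alone, both steps are floors, so their true size stays open, and neither floor clears the usual scatter. Compound 1 and compound 2 each sit at a limit, and the step between them cannot be read: the limit of > 20000 nM in this assay, at which 2 of the 3 values shown sit.

As far as these compounds go, whether an amine, a nitrile or a longer carbon chain on this carbon would give a lower number than iodo remains open. Also open, from the compounds shown here alone, is whether furan-3-yl and 1-benzofuran-2-yl differ at all.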